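The source may report more compounds than this note shows. Statements on the series, on what has been measured and on what is new or still open speak of the compounds shown alone.

Measured so far in a functional assay on aorta with Alpha-1D adrenergic receptor (Rattus norvegicus) as the target; on this read-out higher numbers stand for an effect only at larger amounts of compound and lower numbers for an effect already at smaller amounts:

Compound 1, `O=c1c2ccccc2c(Cc2ccc(Cl)cc2)nn1-c1ccc([N+](=O)[O-])cc1`: 29000 nM
Compound 2, `CSc1ccc(Cc2nn(-c3ccc([N+](=O)[O-])cc3)c(=O)c3ccccc23)cc1`: > 100000 nM, a limit of the assay rather than a number
Compound 3, `COc1ccc(Cc2nn(-c3ccc([N+](=O)[O-])cc3)c(=O)c3ccccc23)cc1OC`: > 100000 nM, likewise a limit

Compound 2 stands at the upper limit of this assay, and (the limit of > 100000 nM in this assay, at which 2 of the 3 values shown sit). Among the measured compounds shown here, compound 1 is the only member of the series with a measured number. Going from it, an at least 3.4-fold higher number from compound 1 to compound 2 (0.53 log units; beyond the scatter) and an at least 3.4-fold higher number from compound 1 to compound 3 (0.53 log units; beyond the scatter) both lie beyond the scatter, while a step that the two limits leave unreadable from compound 2 to compound 3. All three measured steps change the aryl of the benzyl group; none alters the substituent on the aromatic nitrogen of the shared core, so none of them bears directly on the change now considered.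

Compound 4, `CCCCn1nc(Cc2ccc(SC)cc2)c2ccccc2c1=O`, differs from compound 2 as follows: butyl in place of 4-nitrophenyl on an aromatic nitrogen. For the measured compounds named here, with no measured step on this position, no direction can be read from the series; the only anchor is that compound 2 sits at the limit. The working expectation is therefore that compound 4 also lies at or near that limit, with a wide range in both directions.

Compound 4 is estimated at 100000 nM, with a range from 20000 nM to 300000 nM, which corresponds to the expected step of a number no higher from compound 2 to compound 4 (the limit leaves the size open).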

Compound 4, half-maximal effective concentration: > 100000 nM
Compound 4 gave a limit, no number; the forecaster's own chance of this, stated with the estimate: 60%; the middle value sits exactly at the limit.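

Compound 2 and compound 4 both give only a limit, so no step can be read between them, and the size of the change stays unknown: the limit of > 100000 nM in this assay, at which 3 of the 4 values shown sit.

Among the compounds shown here, still open is how butyl in place of 4-nitrophenyl on an aromatic nitrogen acts on the read-out, since compound 1 at 29000 nM remains the only compound here with a measured number.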